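Adding one methoxy to compound 2

This account rests on a few compounds, and the source may have more. Where it says the series, first, only, none or still open, it means among the compounds named here.

In a functional assay on A549 cells (Homo sapiens) for inhibition, read by MTT assay, with a stated time of 72 h (a lower number here means a stronger inhibitor, a higher number a weaker inhibitor), compound 1 (`COc1ccc(/C=C/C(=O)c2c(OC)cc(O)c(CC=C(C)C)c2O)cc1`) gives 38000 nM as its half-maximal inhibitory concentration. Compound 2 (`COc1ccc(/C=C/C(=O)c2c(OC)cc(O)c(CC=C(C)C)c2O)cc1OC`) gives 15700 nM and compound 3 (`COc1cc(OC)c(OC)cc1/C=C/C(=O)c1c(OC)cc(O)c(CC=C(C)C)c1O`) gives 14400 nM on the same read-out. Compound 2 therefore stands level with compound 3 within the scatter, and both carry numbers well under that of compound 1.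

Compound 4 (`COc1cc(/C=C/C(=O)c2c(OC)cc(O)c(CC=C(C)C)c2O)cc(OC)c1OC`) differs from compound 2 by methoxy in place of hydrogen on an aromatic carbon in one place: methoxy in place of hydrogen on an aromatic carbon, ortho to a methoxy group, meta to a methoxy group and meta to a large group.

Two measured steps are of the same kind. One is a 2.4-fold lower number from compound 1 to compound 2 (0.38 log units; beyond the scatter) and counts as modest. The other is a 1.1-fold lower number from compound 2 to compound 3 (0.04 log units; within the scatter) and shows no change beyond the scatter. The second starts from compound 2 itself and so is the closer guide, although its methoxy does not stand where the new one does. Only a small shift towards a lower number is therefore expected in this assay and nothing clearly beyond the scatter. The expected step is a 1.2-fold lower number from compound 2 to compound 4 (0.08 log units; within the scatter) on this reasoning. The estimate for compound 4 is 13000 nM with 6000 nM to 28000 nM as its expected range.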

Compound 4, half-maximal inhibitory concentration: > 50000 nM
Compound 4: no number, only a limit; the forecaster's own chance of this, stated with the estimate: 5%; at least 3.8-fold (0.58 log units) between middle value and limit.
By their numbers in this assay, from the lowest: compounds 3 and 2 (each within the scatter of the next); then compound 1. At a limit, above all of these: compound 4.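

In this assay this position behaves differently from the two earlier methoxy additions: a methoxy on the aromatic carbon ortho to a methoxy group, meta to a methoxy group and meta to a large group gives a step in the opposite direction, an at least 3.1-fold higher number from compound 2 to compound 4 (0.50 log units; beyond the scatter). For compound 4 the read-out is a limit of the assay and not a number: the limit of > 50000 nM in this assay, at which 1 of the 4 values shown sits.

Replacing hydrogen with methoxy on this aromatic ring therefore has no single direction across the series, since compound 2 has the lower number in its step from compound 1, compound 3 stays within the scatter of compound 2, and compound 4 goes against any rule that a further methoxy lowers the number.

On these data alone, how far the true value of compound 4 lies past its limit stays open, and with it the full size of this step. Also open, as far as these compounds go, is whether a smaller or different group in the same place, such as fluorine or an amine, would follow the methoxy or stay level with compound 2.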